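Swapping a Fluorophenyl for an Iodophenyl on the Piperazine Nitrogen

The source may hold more compounds than are shown below. What is called first, only, known or untested is meant among the compounds shown, and "the series" means these compounds.

Of the compounds shown here, three sharing one core have been tested in an assay on CHO cells for displacement of a labelled ligand from adenosine receptor A1 (Homo sapiens), read by scintillation counting, with a stated time of 90 min, tested at 1 uM, in the presence of a further agent that is not named here; a lower number here means less inhibition, a higher number more inhibition at the concentration tested (going by the name of the read-out). Compound 1 `CCCn1c(=O)[nH]c2nc(-c3ccc(S(=O)(=O)N4CCN(c5ccc(Cl)cc5F)CC4)cc3)[nH]c2c1=O` gives 9%, compound 2 `CCCn1c(=O)[nH]c2nc(-c3ccc(S(=O)(=O)N4CCN(c5ccc(C)cc5)CC4)cc3)[nH]c2c1=O` gives 12%, and compound 3 `CCCn1c(=O)[nH]c2nc(-c3ccc(S(=O)(=O)N4CCN(c5cccc(F)c5)CC4)cc3)[nH]c2c1=O` gives 34%, the highest of the three. The change from compound 1 to compound 2 was a number 3 percentage points higher from compound 1 to compound 2 (within the scatter), whereas a number 25 percentage points higher from compound 1 to compound 3 (beyond the scatter) and a number 22 percentage points higher from compound 2 to compound 3 (beyond the scatter) both show a higher number with the 3-fluorophenyl group. Compound 4 `CCCn1c(=O)[nH]c2nc(-c3ccc(S(=O)(=O)N4CCN(c5ccc(I)cc5)CC4)cc3)[nH]c2c1=O` differs from compound 3 by 4-iodophenyl in place of 3-fluorophenyl on an amine nitrogen in a ring. Because a number 25 percentage points higher from compound 1 to compound 3 (beyond the scatter) and a number 22 percentage points higher from compound 2 to compound 3 (beyond the scatter) both rise towards the 3-fluorophenyl, the step to compound 4 is estimated as a drop, a number 19 percentage points lower from compound 3 to compound 4 (beyond the scatter). Compound 4 is therefore expected to give about 15%, between 3% and 30%, in this assay.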

Compound 4, a percentage reported as inhibition, at one concentration (the size of the read-out at that concentration, not a potency): 24%
For compound 4 the middle estimate is 9 percentage points below the measured one; low and high end bracket the measured number.
By their numbers in this assay, from the lowest: compounds 1 and 2 (each within the scatter of the next); then compounds 4 and 3 (each within the scatter of the next).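

On the amine nitrogen in the ring, the 4-iodophenyl group reads much like the 3-fluorophenyl group in this assay (a number 10 percentage points lower from compound 3 to compound 4 (within the scatter)), so the higher numbers are not confined to the 3-fluorophenyl group. Iodo in place of methyl on the same aromatic carbon gives (a number 12 percentage points higher from compound 2 to compound 4 (beyond the scatter)), and the change from the 4-chloro-2-fluorophenyl group gives (a number 15 percentage points higher from compound 1 to compound 4 (beyond the scatter)), so among these compounds a group at that ring position does not by itself set the number. Nothing measured here explains these steps.

Still open, from the compounds shown here alone, is how a plain phenyl or a 4-methoxyphenyl group on this nitrogen would read in this assay.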